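The compounds below may be only part of what the source reports. "The series", "measured", "known", "first", "only" and "open" are said of these compounds alone.

Compound 1 `O=C1/C(=C/c2ccccc2F)CN(S(=O)(=O)c2ccc(F)cc2)C/C1=C\c1ccccc1F` and compound 2 `O=C1/C(=C/c2cccc([N+](=O)[O-])c2)CN(S(=O)(=O)c2ccc(F)cc2)C/C1=C\c1ccccc1F` share one core and differ in a single place: 3-nitrophenyl in place of 2-fluorophenyl on a double-bonded chain carbon bound to a double-bonded ring carbon. In a functional assay on QGY-7703 cells (Homo sapiens) for cytotoxicity, read by MTT assay, with a stated time of 24 h (on this read-out higher numbers stand for weaker inhibition and lower numbers for stronger inhibition), compound 1 gives 8500 nM, and compound 2 gives 14900 nM, so the step of a 1.8-fold higher number from compound 1 to compound 2 (0.24 log units; within the scatter) is a small one. Compound 3 `COc1cc(/C=C2\CN(S(=O)(=O)c3ccc(NC(C)=O)cc3)C/C(=C\c3ccccc3F)C2=O)cc(OC)c1OC` is built on a different core, and the difference between the two cores is not broken down here. In this assay compound 3 gives 2680 nM, the lowest of the three numbers. Compound 4 `COc1cc(/C=C2\CN(S(=O)(=O)c3ccc(NC(C)=O)cc3)C/C(=C\c3cccc([N+](=O)[O-])c3)C2=O)cc(OC)c1OC` differs from compound 3 in the same place where compound 2 differs from compound 1: 3-nitrophenyl in place of 2-fluorophenyl on a double-bonded chain carbon bound to a double-bonded ring carbon. Since the same kind of change is made again, the expected step is a 1.7-fold higher number from compound 3 to compound 4 (0.23 log units; within the scatter), resting on the earlier step of a 1.8-fold higher number from compound 1 to compound 2 (0.24 log units; within the scatter). The expected value for compound 4 in this assay is therefore 4500 nM, most likely falling between 2000 nM and 10000 nM. How compound 4 actually performs in this assay is the measurement that follows.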

Compound 4, half-maximal inhibitory concentration: 2550 nM
For compound 4 the middle estimate is 1.8-fold (0.25 log units) above the measured one, and the stated range covers the measured number.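

In this assay, putting 3-nitrophenyl in place of 2-fluorophenyl on the second core gives a 1.1-fold lower number from compound 3 to compound 4 (0.02 log units; within the scatter), so the swap makes no clear difference on that core. Set beside the same swap on the first core, the two steps agree as far as this scatter allows: the same change on two cores in this assay, a 1.8-fold higher number (0.24 log units; within the scatter) from compound 1 to compound 2 and a 1.1-fold lower number (0.02 log units; within the scatter) from compound 3 to compound 4, 1.8-fold (0.27 log units) apart, within the scatter of two such steps. For the compounds shown here, this shows that the change stays small on both cores, but with only two pairs, and with each step too small to stand out from the scatter, it does not show that the change would stay small on a further core or that the two steps are exactly equal.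

Going by these compounds, all the evidence here concerns a single swap between two aromatic groups, so the effect of a quite different group in that place, such as an amine or a carboxylic acid, remains open. On these data alone, whether the small step would also hold in other cell types remains open too.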